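The source may hold more compounds than are shown below. What is called first, only, known or untested is meant among the compounds shown, and "the series" means these compounds.

Measured in a functional assay on A549 cells (Homo sapiens) for cytotoxicity, read by MTT assay, with a stated time of 72 h; a lower number here means a stronger inhibitor, a higher number a weaker inhibitor:
compound 1 `CCCCN1CCN(CCCCn2c3c(c4ccccc42)C(=O)c2c[n+]([O-])c4ccccc4c2C3=O)CC1`: 550 nM
compound 2 `CN1CCN(CCCn2c3c(c4ccccc42)C(=O)c2c[n+]([O-])c4ccccc4c2C3=O)CC1`: 140 nM

Compound 2 holds the lower of the two numbers in this assay. Compound 3 `O=C1c2c[n+]([O-])c3ccccc3c2C(=O)c2c1c1ccccc1n2CCCN1CCC(O)CC1` is still unmeasured and differs from compound 2 in one group: 4-hydroxypiperidin-1-yl in place of 4-methylpiperazin-1-yl on a saturated chain carbon, three bonds along the chain from an aromatic nitrogen. Within the data shown here, the only measured step, a 3.9-fold lower number from compound 1 to compound 2 (0.59 log units; beyond the scatter), goes with 4-methylpiperazin-1-yl in place of (4-butylpiperazin-1-yl)methyl on the same chain. Among the measured compounds shown here, it shows that this assay responds to a change in this part of the series, but it bears only indirectly, since no measured compound carries 4-hydroxypiperidin-1-yl. The direction is therefore uncertain, and a step of similar modest size is the working expectation, leaning towards a higher number. The expected change is a 1.8-fold higher number from compound 2 to compound 3 (0.25 log units; within the scatter). For compound 3 the estimated value is 250 nM, with an expected range of 70 nM to 800 nM.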

Compound 3, half-maximal inhibitory concentration: 350 nM
Estimate against measurement, compound 3: 1.4-fold (0.15 log units) below; the measured number falls inside the stated range.
By their numbers in this assay, from the lowest: compound 2; then compounds 3 and 1 (each within the scatter of the next).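

In this assay, among these compounds, the exchange of 3-(4-methylpiperazin-1-yl)propyl for 3-(4-hydroxypiperidin-1-yl)propyl gives a 2.5-fold higher number from compound 2 to compound 3 (0.40 log units; beyond the scatter), the first reading of a change in the ring itself with the chain held constant. The other new step, a 1.6-fold lower number from compound 1 to compound 3 (0.20 log units; within the scatter), does not separate these two compounds, so among the three only compound 2 stands apart, with printed steps beyond the scatter to both others. Nothing at hand accounts for either step.

The exchange alters the ring hetero atoms and the hydrogen-bond donors together, and the compounds shown cannot separate these; 4-methylpiperidin-1-yl or morpholin-4-yl on the same propyl chain would address that. As far as these compounds go, the contribution of chain length also remains open, as would be tested by 4-methylpiperazin-1-yl on a butyl chain.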